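Swapping the benzimidazole of compound 3 for a benzoxazole

This account rests on a few compounds, and the source may have more. Where it says the series, first, only, none or still open, it means among the compounds named here.

Measured in a functional assay on HL60/MX2 cells (Homo sapiens) for antiproliferative activity, read by MTT assay, with a stated time of 48 h; on this read-out higher numbers stand for weaker inhibition and lower numbers for stronger inhibition:
- Compound 1 `CCN(CC)CCn1c(N)c(-c2nc3ccccc3[nH]2)c2nc(C#N)c(C#N)nc21`: 7150 nM
- Compound 2 `N#Cc1nc2c(-c3nc4ccccc4[nH]3)c(N)n(CCCO)c2nc1C#N`: > 50000 nM
- Compound 3 `N#Cc1nc2c(-c3nc4ccccc4[nH]3)c(N)n(CCCN3CCCCC3)c2nc1C#N`: 1010 nM

The value for compound 2 is a limit of the assay and not a number. This is the only such case in the set: the limit of > 50000 nM in this assay, at which 1 of the 3 values shown sits.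

Compound 3 stands best of the three in this assay, with the lowest number at 1010 nM. The next step leads to compound 4 `N#Cc1nc2c(-c3nc4ccccc4o3)c(N)n(CCCN3CCCCC3)c2nc1C#N`, which keeps the 3-(piperidin-1-yl)propyl group and the shared core. Here 1,3-benzoxazol-2-yl replaces 1H-benzimidazol-2-yl on an aromatic carbon: 1,3-benzoxazol-2-yl in place of 1H-benzimidazol-2-yl on an aromatic carbon.

Among the compounds with values here, none of the measured steps touches this place. All three change the chain end instead: an at least 6.9-fold higher number from compound 1 to compound 2 (0.84 log units; beyond the scatter), a 7.1-fold lower number from compound 1 to compound 3 (0.85 log units; beyond the scatter) and an at least 49-fold lower number from compound 2 to compound 3 (1.69 log units; beyond the scatter). They show that this read-out can move clearly when the structure changes, but they give neither a size nor a direction for the swap in compound 4. The expectation therefore starts from compound 3 at 1010 nM, and no step beyond the scatter is firmly expected. The estimated change is small: a 1.5-fold higher number from compound 3 to compound 4 (0.17 log units; within the scatter). The range stays wide, and a clear move either way would not be surprising. Compound 4 is expected at about 1500 nM, within an estimated range from 250 nM to 7000 nM.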

Compound 4, half-maximal inhibitory concentration: 5450 nM
Beside the measured number, compound 4's estimate is 3.6-fold (0.56 log units) below it; measured number inside the range.
By their numbers in this assay, from the lowest: compound 3; then compounds 4 and 1 (each within the scatter of the next). At a limit, above all of these: compound 2.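

Within the data shown here, this is the first measured change at this aromatic carbon, and it shows that the group here counts as much as the chain end: in this assay, 1,3-benzoxazol-2-yl in place of 1H-benzimidazol-2-yl gives a 5.4-fold higher number from compound 3 to compound 4 (0.73 log units; beyond the scatter). The two groups have the same heavy-atom count and ring sizes, but the entering group has an oxygen in place of one nitrogen and goes from 1 hydrogen-bond donor and 1 acceptor to 0 donors and 2 acceptors, so a small exchange within the ring system is enough to move this read-out. No measurement shown here speaks to the reason for this move.

This single pair cannot separate the loss of the donor from the gain of the oxygen, and a 1-methylbenzimidazol-2-yl group, with a methyl on the ring nitrogen, or a 1,3-benzothiazol-2-yl group, with sulfur in the ring, would help to pull the two apart. Going by these compounds, it also stays open whether the same swap would move the number similarly with another chain, such as the 2-(diethylamino)ethyl chain of compound 1.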